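This account rests on a few compounds, and the source may have more. Where it says the series, first, only, none or still open, it means among the compounds named here.

Working notes on the series in a functional assay on the whole organism with Mus musculus as the target, in the writhing test; on this read-out higher numbers stand for an effect only at larger amounts of compound and lower numbers for an effect already at smaller amounts.

Of the compounds shown here, three have numbers so far. Compound 1 `CCCn1nc(C)c2c(C)cc(=O)oc21` gives 54.3 mg/kg in this assay. Compound 2 `CCn1nc2oc(=O)cc(C)c2c1C` gives 14.6 mg/kg in this assay and holds the lowest of the two numbers; the nearest is compound 1, whose higher number lies beyond the usual scatter. Within the data shown here, no step between two measured compounds that differ in a single place is available, so the gap between compound 2 and compound 1 is recorded only as what the two values show. For compound 3 `CCOC(=O)Cc1nnc2oc(O)cc(C)c1-2` this assay reports only a limit, > 100 mg/kg, which is a limit of the assay and not a number; this is the limit of > 100 mg/kg in this assay, at which 1 of the 3 values shown sits.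

Compound 4 `CCCn1nc2oc(=O)cc(C)c2c1C` has not yet been measured in this assay. It differs from compound 2 by methyl in place of hydrogen on a saturated chain carbon, two bonds along the chain from an aromatic nitrogen, which read one bond further out is ethyl to propyl. Among the measured compounds shown here, no measured pair isolates this change, so the step is expected to be small, likely toward a somewhat higher number, and may well stay within the scatter. On that basis compound 4 is expected to give 22 mg/kg in this assay, with a plausible range from 8 mg/kg to 55 mg/kg. The step this estimate implies is a 1.5-fold higher number from compound 2 to compound 4 (0.18 log units; within the scatter), an expected rather than a measured value.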

Compound 4, dose for half-maximal effect: 72.6 mg/kg
The estimate for compound 4 lay 3.3-fold (0.52 log units) below the measured number, outside the stated range (above it).
By their numbers in this assay, from the lowest: compound 2; then compounds 1 and 4 (each within the scatter of the next). At a limit, above all of these: compound 3.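

Methyl in place of hydrogen on a saturated chain carbon, two bonds along the chain from an aromatic nitrogen, read one bond further out as ethyl to propyl, gives in this assay a 5.0-fold higher number from compound 2 to compound 4 (0.70 log units; beyond the scatter), so this position responds to a single added carbon by more than the usual scatter. Among these compounds, this is the first pair that isolates a change at this chain, and with one pair the finding holds only for this lengthening on this core, with no trend along a chain to be drawn from it. Nothing at hand gives a cause for this step.

As far as these compounds go, whether the number keeps rising with a longer chain such as butyl, or how a chain ending in an amine or a carboxylic acid would read at the same place, stays open. Among the compounds shown here, compound 3 gives > 100 mg/kg, which is a limit of the assay and not a number, so it adds no step to this reading.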